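This account rests on a few compounds, and the source may have more. Where it says the series, first, only, none or still open, it means among the compounds named here.

Measured compounds:
- compound 1, `c1cncc(N2CC[C@H]3CN[C@H]3C2)c1`: in a functional assay on HEK293 cells for agonist activity at Neuronal acetylcholine receptor; alpha4/beta2 (Homo sapiens), read by FLIPR (a higher number here means that more compound is needed for the effect, a lower number that less compound is needed), compound 1 gives 71 nM
- compound 2, `c1cncc(N2CC[C@@H]3CN[C@@H]3C2)c1`: in this assay compound 2 gives 330 nM

Compound 2 stands at the higher of the two numbers, so more of it is needed for the same effect than of compound 1. Going by the values given here, the only measured step is the one between these two, a 4.6-fold higher number from compound 1 to compound 2 (0.67 log units; beyond the scatter), and it rests on the fact that compounds 1 and 2 differ only in the configuration as drawn: the two are mirror images of one another, nothing else is changed.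

Compound 3, `COc1cncc(N2CC[C@@H]3CN[C@@H]3C2)c1`, keeps the configuration of compound 2 and adds a small group to the aromatic ring: methoxy in place of hydrogen on an aromatic carbon. Among the compounds with values here, no measured step speaks to a change of this kind; the one step known describes only an inversion of configuration, not a substituent on the ring. The expectation for compound 3 can therefore rest only on where compound 2 stands, with a wide range around it. A step of a 1.2-fold higher number from compound 2 to compound 3 (0.08 log units; within the scatter) is expected, which could in practice fall either way from compound 2. Compound 3 is estimated to give 400 nM in this assay, within a range from 100 nM to 1600 nM.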

Compound 3, half-maximal effective concentration: 2700 nM
Compound 3: middle estimate off by 6.8-fold (0.83 log units), on the low side; the measured number lies above the stated range.
By their numbers in this assay, from the lowest: compound 1; then compound 2; then compound 3.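

Going by these compounds alone, this step is the first measured sign that the aromatic ring of the series is sensitive to substitution: in this assay, methoxy in place of hydrogen on an aromatic carbon, two atoms from the ring nitrogen, gives an 8.2-fold higher number from compound 2 to compound 3 (0.91 log units; beyond the scatter). So more compound is needed once this hydrogen is replaced, and the earlier pair, which differs only in configuration, could not show that; alongside a 4.6-fold higher number from compound 1 to compound 2 (0.67 log units; beyond the scatter), there are now two kinds of change in this small set that move the number beyond the scatter. Nothing measured among these compounds accounts for the effect of the methoxy group at this position.

Going by these compounds, it remains open whether the step belongs to methoxy itself or would also appear with another group at the same place, such as fluorine, an amine or a longer chain such as ethoxy, and whether the same position behaves differently when substituted elsewhere on the ring. It is also open whether methoxy would change the number to a similar extent on the mirror-image core of compound 1, since the one step shown belongs to the configuration of compound 2.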